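A few compounds are considered here, and "the series" means these few. Any claim that something is new, unique, unknown or untested is made for them only; others in the source may bear on it.

In a functional assay on MDA-MB-231 cells (Homo sapiens) for antiproliferative activity, read by XTT assay, with a stated time of 48 h (a higher number here means a weaker inhibitor, a lower number a stronger inhibitor), compound 1 `COc1cccc(N(Cc2cn([C@@H]3O[C@H](COC(C)=O)[C@@H](OC(C)=O)[C@H](OC(C)=O)[C@H]3OC(C)=O)nn2)S(C)(=O)=O)c1` gives 220000 nM and compound 2 `CC(=O)OC[C@H]1O[C@@H](n2cc(CN(c3ccc(C#N)cc3)S(C)(=O)=O)nn2)[C@H](OC(C)=O)[C@@H](OC(C)=O)[C@@H]1OC(C)=O` gives 215000 nM, so compound 2 stands level with compound 1 within the scatter. Compound 3 `COC(=O)CN(Cc1cn([C@@H]2O[C@H](COC(C)=O)[C@@H](OC(C)=O)[C@H](OC(C)=O)[C@H]2OC(C)=O)nn1)S(C)(=O)=O` returns only a limit, > 250000 nM. Compound 4 `CC(=O)OC[C@H]1O[C@@H](n2cc(CN(c3ccc(C#N)cc3)S(C)(=O)=O)nn2)[C@H](OC(C)=O)[C@@H](OC(C)=O)[C@H]1OC(C)=O` departs from compound 2 in a single respect: the two compounds have the same atoms and bonds and differ only in configuration as drawn: 1 of 5 stereo elements differ; a stereocentre at a saturated ring carbon is drawn R in compound 2 and S in compound 4.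

Among the measured compounds shown here, no measured step tests a change of configuration, so the evidence bears on this change only indirectly. All three measured steps replace the group on a sulfonamide nitrogen. Going to 4-cyanophenyl in place of 3-methoxyphenyl gives a 1.0-fold lower number from compound 1 to compound 2 (0.01 log units; within the scatter). Going to (methoxycarbonyl)methyl gives an at least 1.1-fold higher number from compound 1 to compound 3 (0.05 log units; that floor lies within the scatter) and an at least 1.1-fold higher number from compound 2 to compound 3 (0.06 log units; that floor lies within the scatter). Even these changes of group leave the numbers within the scatter, although the last two steps are bounded on one side only. For the measured compounds named here, the series therefore offers no precedent for a sizeable shift, and no step beyond the scatter is expected in this assay. The expected step is a 1.0-fold lower number from compound 2 to compound 4 (0.02 log units; within the scatter), with no direction firmly indicated. The measured numbers sit close to the limit of > 250000 nM in this assay, at which 1 of the 3 values shown sits, so it is expected that compound 4 could also return only a limit. If a number is obtained, the estimate for compound 4 is 205000 nM, with an expected range from 120000 nM to 250000 nM.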

Compound 4, half-maximal inhibitory concentration: 100000 nM
Estimate against measurement, compound 4: 2.1-fold (0.31 log units) above, outside the stated range (below it).
By their numbers in this assay, from the lowest: compound 4; then compounds 2 and 1 (each within the scatter of the next). At a limit, above all of these: compound 3.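

In this assay, among the compounds shown here, the configuration at this one saturated ring carbon produces the first step that is read as lying beyond the scatter: a 2.2-fold lower number from compound 2 to compound 4 (0.33 log units; beyond the scatter). For the compounds shown here, the earlier changes of the group on the sulfonamide nitrogen showed no such step, as 4-cyanophenyl and 3-methoxyphenyl left compounds 2 and 1 level within the scatter, while the steps to compound 3 are bounded on one side only and their floors also lie within the scatter. The shift, though modest, can be assigned to that single stereocentre because no other structural feature separates the pair: the fact that compounds 2 and 4 differ only in the configuration as drawn

The compounds shown leave open whether the same inversion would lower the number in the same way with 3-methoxyphenyl or (methoxycarbonyl)methyl on the sulfonamide nitrogen, and whether the other stereocentres of the shared core are equally sensitive to such a change. On these data alone, it also remains open whether the step would persist if free hydroxyl groups stood in place of the acetate esters, or if an aryl group bearing an amine or a carboxylic acid replaced 4-cyanophenyl.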